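A few compounds are considered here, and "the series" means these few. Any claim that something is new, unique, unknown or untested is made for them only; others in the source may bear on it.

Of the compounds shown here, three sharing one core have so far been tested in a functional assay on PC-9 cells (Homo sapiens) for inhibition, read by MTT assay, with a stated time of 48 h, tested at 10 uM; on this read-out higher numbers stand for more inhibition at the one concentration tested (going by the name of the read-out) and lower numbers for less inhibition. Compound 1 `COc1cc(NC(=O)Nc2cc(Nc3cc(Br)ccc3OC)ncn2)cc(OC)c1` gives 82.5%. Compound 2 `Cc1ccc(Nc2cc(NC(=O)Nc3c(Cl)cccc3Cl)ncn2)cc1F` gives 92%, and compound 3 `Cc1ccc(Nc2cc(NC(=O)Nc3c(Cl)cccc3Cl)ncn2)cc1C` gives 92.1%. For the measured compounds named here, the only one-place step among the three, a number 0.1 percentage points higher from compound 2 to compound 3 (within the scatter), lies within the scatter. Compound 1 holds the lowest of the three numbers, yet its gaps to compound 2 and to compound 3 both lie within the scatter as well, so the three figures cannot be placed in any order.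

Compound 4 `COc1cc(NC(=O)Nc2cc(Nc3cc(I)ccc3OC)ncn2)cc(OC)c1` is the next to be measured. It differs from compound 1 in a single place: iodo in place of bromo on an aromatic carbon. The halogen sits on an aromatic carbon of a six-membered aromatic ring of carbon only, meta to a large group and para to a methoxy group. No measured step concerns a halogen exchange of this kind; the one step shown concerns methyl in place of fluoro elsewhere on the shared core and stayed within the scatter, so it gives no direction. Going by the values given here, with no bearing step, the expected change for compound 4 in this assay is a number 0.5 percentage points lower from compound 1 to compound 4 (within the scatter), nothing beyond the scatter. Compound 4 is therefore estimated to give 82%, with a range from 70% to 93%.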

Compound 4, a percentage reported as inhibition, at one concentration (the size of the read-out at that concentration, not a potency): 91%
Estimate against measurement, compound 4: 9 percentage points below; the range from low to high includes it.
By their numbers in this assay, from the lowest: compounds 1, 4, 2 and 3 (each within the scatter of the next).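

The exchange of bromo for iodo, on an aromatic carbon meta to a large group and para to a methoxy group, gives a number 8.5 percentage points higher from compound 1 to compound 4 (within the scatter) in this assay. For the compounds shown here, this is the first reading of any change at this position, and it shows that the 5-bromo-2-methoxyphenyl and 5-iodo-2-methoxyphenyl forms cannot be told apart on this read-out, with compound 1 at 82.5% and compound 4 at 91%. Nothing is available beyond these numbers that bears on the exchange.

On these data alone, whether this position needs a halogen at all remains open: an amine or a carboxylic acid on the same carbon could leave the number close to that of compound 4 or shift it beyond the scatter. As far as these compounds go, because the read-out gives the size of the inhibition at a single concentration and not a potency, it also remains open whether compound 1 and compound 4 would separate across a range of concentrations.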